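The source may hold more compounds than are shown below. What is called first, only, known or untested is meant among the compounds shown, and "the series" means these compounds.

Compound 1 `CC(C)CNc1ccc(NC(=O)c2cc(Cl)ccc2O)c(Cl)c1` gives 60000 nM
Compound 2 `O=C(Nc1ccc(NCC2CC2)cc1Cl)c1cc(Cl)ccc1O` gives 14400 nM
Compound 3 `O=C(Nc1ccc(NC2CCCCC2)cc1Cl)c1cc(Cl)ccc1O` gives 68300 nM

These values come from an ADME assay on A549 cells (Homo sapiens) for cytotoxicity, read by resazurin assay, with a stated time of 48 h; on this read-out higher numbers stand for lower toxicity in this test and lower numbers for higher toxicity in this test. Compound 3 shares the upper end of the three numbers with compound 1, the step between them being a 1.1-fold higher number from compound 1 to compound 3 (0.06 log units; within the scatter). Compound 2 stands clearly lower, and the step up from it is a 4.7-fold higher number from compound 2 to compound 3 (0.68 log units; beyond the scatter).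

Compound 4 `CN(C)c1ccc(NC(=O)c2cc(Cl)ccc2O)c(Cl)c1` carries dimethylamino in place of cyclohexylamino on an aromatic carbon. Going by the values given here, no measured compound carries dimethylamino, so no measured step matches this change directly. The nearest evidence comes from the steps that alter the group on the same nitrogen. One of these, a 4.2-fold lower number from compound 1 to compound 2 (0.62 log units; beyond the scatter), shows that a change there can lower the number modestly. The step from compound 1 to compound 3 shows that such a change can also leave it within the scatter. The measured values therefore span only a modest range, and a small group need not give a large shift. A modest move to a lower number is expected, and the expected step is a 2.3-fold lower number from compound 3 to compound 4 (0.36 log units; beyond the scatter). For compound 4 the estimated value is 30000 nM, with an expected range from 10000 nM to 90000 nM.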

Compound 4, half-maximal cytotoxic concentration: 85100 nM
Beside the measured number, compound 4's estimate is 2.8-fold (0.45 log units) below it; the range from low to high includes it.
By their numbers in this assay, from the lowest: compound 2; then compounds 1, 3 and 4 (each within the scatter of the next).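

In this assay the position on the aromatic carbon para to a large group accepts a much smaller substituent: dimethylamino has no ring and no hydrogen-bond donor, unlike cyclohexylamino, yet the result is a 1.2-fold higher number from compound 3 to compound 4 (0.10 log units; within the scatter) and the change from the open-chain isobutylamino gives a 1.4-fold higher number from compound 1 to compound 4 (0.15 log units; within the scatter) as well. Compounds 1, 3 and 4 therefore sit together across groups of quite different size, and only compound 2 goes against this, with a 5.9-fold higher number from compound 2 to compound 4 (0.77 log units; beyond the scatter) showing that (cyclopropylmethyl)amino remains the one group here tied to a clearly lower number, so the hydrogen on this nitrogen is not needed to keep the number up among these compounds. No evidence is available on why the numbers fall this way.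

The compounds shown leave open whether the lower number of compound 2 is particular to the cyclopropylmethyl group or would recur with a cyclobutylmethyl group or a plain unsubstituted amino group at this position. They also leave open how a chain ending in a carboxylic acid or a morpholine ring would behave here.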